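The source may hold more compounds than are shown below. What is called first, only, known or untested is meant among the compounds shown, and "the series" means these compounds.

Measured so far in a functional assay on MGC-803 cells (Homo sapiens) for antiproliferative activity, read by MTT assay, with a stated time of 48 h; a lower number here means a stronger inhibitor, a higher number a weaker inhibitor:
- compound 1 `COc1ccc(CN(C(=O)Cn2cc(COc3ccc4ccc(=O)oc4c3)nn2)c2cc(OC)c(OC)c(OC)c2)cc1` gives 180 nM
- compound 2 `COc1ccc(CN(C(=O)Cn2cc(CSC3=NCCS3)nn2)c2cc(OC)c(OC)c(OC)c2)cc1` gives 1610 nM

Of these two numbers, compound 2 holds the higher one, 1610 nM, so it is the weaker of the pair. Next is compound 3 `COc1ccc(CN(C(=O)Cn2cc(CSc3nc4ccccc4o3)nn2)c2cc(OC)c(OC)c(OC)c2)cc1`, whose change from compound 2 is a group of 9 heavy atoms (7 carbon, 1 nitrogen, 1 oxygen; one five-membered aromatic ring with 2 hetero atoms, one six-membered aromatic ring of carbon only) in place of a group of 5 heavy atoms (3 carbon, 1 nitrogen, 1 sulfur; one five-membered non-aromatic ring with 2 hetero atoms), on a sulfur; the entering group is 1,3-benzoxazol-2-yl. For the measured compounds named here, only one measured step bears on this: an 8.9-fold higher number from compound 1 to compound 2 (0.95 log units; beyond the scatter). There, a group with two aromatic rings left and a five-membered non-aromatic ring entered. The new change runs the opposite way, but with a different pair of aromatic rings, and one step is thin evidence. Only part of that gap is therefore expected to return in this assay, as a lower number. The expected change is a 3.2-fold lower number from compound 2 to compound 3 (0.51 log units; beyond the scatter), an estimate only. The estimated value for compound 3 is 500 nM, with an expected range from 130 nM to 1900 nM as its limits.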

Compound 3, half-maximal inhibitory concentration: 1850 nM
The estimate for compound 3 lay 3.7-fold (0.57 log units) below the measured number, within the range that was stated.
By their numbers in this assay, from the lowest: compound 1; then compounds 2 and 3 (each within the scatter of the next).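

In this assay, 1,3-benzoxazol-2-yl on the sulfur in place of the five-membered non-aromatic ring gives a 1.1-fold higher number from compound 2 to compound 3 (0.06 log units; within the scatter), so at this sulfur, a group with two aromatic rings is not separated from the non-aromatic ring. Two aromatic rings in the entering group are therefore not enough to reach the number of compound 1: the change of its group for the sulfur-linked 1,3-benzoxazol-2-yl gives a 10-fold higher number from compound 1 to compound 3 (1.01 log units; beyond the scatter). No measurement at hand explains either step.

On these data alone, whether the large step from compound 1 goes with the sulfur link or with the ring pair stays open, as the two change together there. Also open, as far as these compounds go, is how a morpholine or a primary amine on the saturated chain carbon would read in this assay.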